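The compounds below may be only part of what the source reports. "The series", "measured", "known", "first", "only" and "open" are said of these compounds alone.

Measured in an ADME assay on HEK293 cells (Homo sapiens) for cytotoxicity; a lower number here means a stronger inhibitor, a higher number a weaker inhibitor:
- compound 1, `COC(=O)c1c(C)cc(OC(=O)c2c(C)cc(O)c(/C=N/NC(=O)Cc3ccccc3)c2O)c(C)c1O`: > 100000 nM, a limit
- compound 2, `COC(=O)c1c(C)cc(OC(=O)c2c(C)cc(O)c(/C=N/NC(=O)COc3ccc(Br)cc3)c2O)c(C)c1O`: > 100000 nM, a limit

Neither compound has an actual number, so compound 1 stands only at a limit. Both share one reading, (the limit of > 100000 nM in this assay, at which 2 of the 2 values shown sit).

Compound 3, `COC(=O)c1c(C)cc(OC(=O)c2c(C)cc(O)c(/C=N/NC(=O)CSc3nc4ccccc4s3)c2O)c(C)c1O`, has not yet been measured. It carries (1,3-benzothiazol-2-yl)sulfanyl in place of phenyl on a saturated chain carbon bound to a carbonyl carbon.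

One measured change bears on this, at the same place, with 4-bromophenoxy entering in place of phenyl: a step that the two limits leave unreadable from compound 1 to compound 2. It offers no size to carry over, but that larger replacement also left this assay without a number. No clear direction can be drawn from it, so only a small change is expected, and another limit is the likeliest result.

The expected change is a number no higher from compound 1 to compound 3 (the limit leaves the size open). For compound 3 the estimate is 100000 nM, with an expected range from 30000 nM to 200000 nM.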

Compound 3, half-maximal inhibitory concentration: 70100 nM
Compound 3: middle estimate off by 1.4-fold (0.15 log units), on the high side; low and high end bracket the measured number.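

In this assay, compound 3 gives the first actual number on this saturated chain carbon bound to a carbonyl carbon, where the earlier compounds stop at a limit: the limit of > 100000 nM in this assay, at which 2 of the 3 values shown sit.

Putting (1,3-benzothiazol-2-yl)sulfanyl in place of phenyl gives an at least 1.4-fold lower number from compound 1 to compound 3 (0.15 log units; that floor lies within the scatter), and putting it in place of 4-bromophenoxy gives an at least 1.4-fold lower number from compound 2 to compound 3 (0.15 log units; that floor lies within the scatter). Going by these compounds, both figures are only floors that lie within the scatter, so this change brings a readable value into the assay range, but its true size remains unknown.

The sulfur link and the 1,3-benzothiazol-2-yl ring system enter together, which leaves open which of them goes with the readable value. Also open, on these data alone, is what phenylsulfanyl, an amine or a carboxylic acid would give at this place.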